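The compounds below may be only part of what the source reports. "The series", "measured", "known", "first", "only" and "open" are said of these compounds alone.

Measured so far:
compound 1 `O=C(Nc1ccccc1[N+](=O)[O-])c1ccc(/N=N\c2c[nH]c3ccccc23)cc1`, 101000 nM
compound 2 `Cc1ccc(C)c(NC(=O)c2ccc(/N=N\c3c[nH]c4ccccc34)cc2)c1`, 29900 nM

In a functional assay on MCF7 cells (Homo sapiens) for inhibition, read by MTT assay, with a stated time of 72 h (on this read-out higher numbers stand for weaker inhibition and lower numbers for stronger inhibition), compound 2 holds the lowest of the two numbers; the step of a 3.4-fold lower number from compound 1 to compound 2 (0.53 log units; beyond the scatter) set it apart from compound 1. Compound 3 `Cc1ccc(NC(=O)c2ccc(/N=N\c3c[nH]c4ccccc34)cc2)c(C)c1` differs from compound 2 by 2,4-dimethylphenyl in place of 2,5-dimethylphenyl on an amide-type nitrogen. Within the data shown here, no measured step touches this kind of change: the only step in hand swaps the whole ring substituent, not the position of a methyl on it, so it gives no direction. A step of a 1.0-fold higher number from compound 2 to compound 3 (0.00 log units; within the scatter) within the scatter is therefore expected. Compound 3 is estimated at 30000 nM, with a range of 10000 nM to 90000 nM.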

Compound 3, half-maximal inhibitory concentration: 87000 nM
The estimate for compound 3 lay 2.9-fold (0.46 log units) below the measured number, within the range that was stated.
By their numbers in this assay, from the lowest: compound 2; then compounds 3 and 1 (each within the scatter of the next).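

In this assay the placing of the methyl groups alone matters: 2,4-dimethylphenyl in place of 2,5-dimethylphenyl on the amide-type nitrogen gives a 2.9-fold higher number from compound 2 to compound 3 (0.46 log units; beyond the scatter) with the same atoms joined differently. 2,4-dimethylphenyl in place of 2-nitrophenyl gives a 1.2-fold lower number from compound 1 to compound 3 (0.06 log units; within the scatter) and so the lower number of compound 2 belongs to 2,5-dimethylphenyl, not to dimethylphenyl as such. No evidence in hand accounts for this gap. Still open, from the compounds shown here alone, is whether a single methyl group keeps the number of compound 2, and how a methoxy group or an amine on this ring reads.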